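This account rests on a few compounds, and the source may have more. Where it says the series, first, only, none or still open, it means among the compounds named here.

In a functional assay on SMMC-7721 cells (Homo sapiens) for inhibition, read by CCK-8 assay, with a stated time of 72 h, tested at 8 uM; on this read-out lower numbers stand for less inhibition of growth and higher numbers for more inhibition of growth at the one concentration tested:
- compound 1 `Nc1ccccc1NC(=O)/C=C/c1ccc(CSc2ccc(Cl)cc2)cc1`: 16.5%
- compound 2 `COc1ccc(SCc2ccc(C(=O)Nc3ccccc3N)cc2)cc1`: 80.1%

Compound 1 is the lower of the two numbers, and the gap to compound 2 lies beyond the scatter. Compound 3 `Cc1ccc(SCc2ccc(/C=C/C(=O)Nc3ccccc3N)cc2)cc1` keeps the core of compound 1 and changes one group: methyl in place of chloro on an aromatic carbon. Among the compounds with values here, no measured pair shows this swap alone, so the expectation rests on compound 1 at 16.5%, with no step beyond the scatter expected. The expected change is a number 5.5 percentage points higher from compound 1 to compound 3 (within the scatter). For compound 3 the estimated value is 22%, with an expected range of 6% to 45%.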

Compound 3, percent growth inhibition at one concentration: 22.2%
Compound 3: the middle estimate sits 0.2 percentage points below what was measured; measured number inside the range.
By their numbers in this assay, from the lowest: compounds 1 and 3 (each within the scatter of the next); then compound 2.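

In this assay, within the data shown here, the first single change that can be read gives a number 5.7 percentage points higher from compound 1 to compound 3 (within the scatter) on swapping chloro for methyl. At this place on the ring, para to a large group, the two groups cannot be told apart at the one concentration tested. Nothing at hand explains this result.

On these data alone, it remains open whether an amine or a carboxylic acid at the same place would shift growth inhibition beyond the scatter. A longer chain, such as propyl, poses the same open question.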